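Swapping 4-Chlorophenyl for Methyl on a Ring Nitrogen

The source may report more compounds than this note shows. Statements on the series, on what has been measured and on what is new or still open speak of the compounds shown alone.

Compound 1 `Nc1ccccc1NC(=O)c1ccc(CSC(=S)N2CCN(c3ccc(Cl)cc3)CC2)cc1`: 32.2%
Compound 2 `Nc1ccccc1NC(=O)c1ccc(CSC(=S)N2CCc3cc(Cl)ccc32)cc1`: 31.9%
Compound 3 `CC1CCCCN1C(=S)SCc1ccc(C(=O)Nc2ccccc2N)cc1`: 42.5%

In a functional assay on A-375 cells (Homo sapiens) for antiproliferative activity, read by CCK-8 assay, with a stated time of 72 h, tested at 2 uM (on this read-out higher numbers stand for a stronger effect at the one concentration tested and lower numbers for a weaker effect), compound 1 gives 32.2%, the second highest of the three numbers; compound 2 lies within the scatter of it, while compound 3 stands beyond the scatter above it. Compound 4 `CN1CCN(C(=S)SCc2ccc(C(=O)Nc3ccccc3N)cc2)CC1` differs from compound 1 by methyl in place of 4-chlorophenyl on an amine nitrogen in a ring. Within the data shown here, no measured step changes this nitrogen. Among the measured compounds shown here, the only step known, a number 10.6 percentage points higher from compound 2 to compound 3 (beyond the scatter), concerns a different place, the thiocarbonyl carbon, where a chlorine-bearing aromatic group gave way to a saturated ring. Its size suggests that exchanging a chlorine-bearing aromatic group for a small saturated group can move this read-out modestly upward. For compound 4 a step of a number 5.8 percentage points higher from compound 1 to compound 4 (within the scatter) is therefore expected, small and upward. The estimate for compound 4 is 38%, between 24% and 52%.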

Compound 4, a percentage reported as inhibition, at one concentration (the size of the read-out at that concentration, not a potency): 36.6%
The estimate for compound 4 lay 1.4 percentage points above the measured number; measured number inside the range.
By their numbers in this assay, from the lowest: compounds 2, 1, 4 and 3 (each within the scatter of the next, the first and the last beyond it).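

The ring nitrogen now has a measured step in this assay: a number 4.4 percentage points higher from compound 1 to compound 4 (within the scatter), so methyl in place of 4-chlorophenyl does not shift the read-out beyond the scatter. On the thiocarbonyl carbon, 4-methylpiperazin-1-yl stays within the scatter of both other groups, with a number 5.9 percentage points lower from compound 3 to compound 4 (within the scatter) and a number 4.7 percentage points higher from compound 2 to compound 4 (within the scatter), although those two groups differ beyond the scatter from each other. No available measurement accounts for these results.

From the compounds shown here alone, whether a carboxylic acid or a longer chain on this ring nitrogen would move the read-out beyond the scatter remains open.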